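A Hydroxyl Swap on the Sulfonyl Ring, Judged Beforehand

The source may hold more compounds than are shown below. What is called first, only, known or untested is meant among the compounds shown, and "the series" means these compounds.

Compound 1 `Cc1ccccc1S(=O)(=O)Nc1ccc2oc(-c3ccccc3)nc2c1` carries a 2-methylphenyl on its sulfonyl sulfur. In an assay on isolated protein for inhibition of malate dehydrogenase, mitochondrial (Sus scrofa), with stated times of 45 min and 30 min (on this read-out lower numbers stand for stronger inhibition and higher numbers for weaker inhibition), compound 1 returns only a limit, > 63000 nM. Its two companions share this outcome. Compound 2 `Cc1cccc(S(=O)(=O)Nc2ccc(-c3nc4ccccc4o3)cc2)c1` gives in this assay a limit of > 63000 nM. Compound 3 `O=S(=O)(Nc1ccc2oc(-c3ccccc3)nc2c1)c1ccc(Cl)c(C(F)(F)F)c1` likewise reaches only a limit of > 63000 nM. Among the compounds with values here, the whole picture so far is the limit of > 63000 nM in this assay, at which 3 of the 3 values shown sit, so no measured step exists to size any change, and compound 1 stands at the same limit as the other two rather than anywhere on a numbered scale.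

Compound 4 `O=S(=O)(Nc1ccc2oc(-c3ccccc3)nc2c1)c1ccc(O)cc1` has not yet been measured. It differs from compound 1 in one place: 4-hydroxyphenyl in place of 2-methylphenyl on a sulfonyl sulfur. With no measured step in hand, this change cannot be sized from the shown compounds, and the author expects nothing beyond the scatter, in the sense that compound 4 is expected to stay at the limit. The expected step is a step that the limit leaves unreadable from compound 1 to compound 4. The estimate for compound 4 in this assay is 80000 nM, expected to lie between 20000 nM and 300000 nM.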

Compound 4, half-maximal inhibitory concentration: > 63000 nM
Compound 4: a limit, no number; the forecaster's own chance of this, stated with the estimate: 75%; the middle value lies beyond the limit too.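

In this assay, within the data shown here, compound 1 and compound 4 both return only limits, so no step between them can be read: the limit of > 63000 nM in this assay, at which 4 of the 4 values shown sit. The compounds shown leave open whether in this assay any group on the sulfonyl sulfur brings a readable number.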